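From naphthalen-1-yl to 4-methoxyphenyl in a growth inhibition series

A few compounds are considered here, and "the series" means these few. Any claim that something is new, unique, unknown or untested is made for them only; others in the source may bear on it.

Of the compounds shown here, three have been measured in a functional assay on PC-3 cells (Homo sapiens) for inhibition, read by sulforhodamine B assay, with a stated time of 48 h, tested at 50 uM; on this read-out lower numbers stand for less inhibition of growth and higher numbers for more inhibition of growth at the one concentration tested. In this test, compound 1 `COc1cc(/C=C/C(=O)/C=C/c2cccc3ccccc23)ccc1OCc1cn(CCOc2cc(=O)oc3ccccc23)nn1` gives 20%, and compound 3 `COc1cc(/C=C/C(=O)/C=C/c2cc(OC)c(OC)c(OC)c2)ccc1OCc1cn(CCCCOc2cc(=O)oc3ccccc23)nn1` gives 5%. Compound 2 `COc1cc(/C=C/C(=O)/C=C/c2ccco2)ccc1OCc1cn(CCCCOc2cc(=O)oc3ccccc23)nn1` is recorded as "not active" (no number reported), with no number reported. Among the measured compounds shown here, compound 1 therefore holds the higher of the only two numbers available, and its lead over compound 3 lies beyond the usual scatter. Even so, this is weak inhibition at the single concentration tested.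

Compound 4 `COc1ccc(/C=C/C(=O)/C=C/c2ccc(OCc3cn(CCOc4cc(=O)oc5ccccc45)nn3)c(OC)c2)cc1` has not yet been measured in this assay. It departs from compound 1 in one place: 4-methoxyphenyl in place of naphthalen-1-yl on a double-bonded chain carbon bound to a double-bonded chain carbon. For the measured compounds named here, no measured pair differs in just one place, so the effect of this change has not been isolated. The closest hint is compound 3, which also carries methoxy groups on the aryl ring at this end of the chain and gives 5%. That single comparison is confounded by other differences, so it supports only a small expected decline. The expected a number 8 percentage points lower from compound 1 to compound 4 (within the scatter) is modest and lies within the scatter. For compound 4 the estimated value is 12%, with an expected range of 0% to 30%.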

Compound 4, percent growth inhibition at one concentration: 15%
Estimate against measurement, compound 4: 3 percentage points below, within the range that was stated.
By their numbers in this assay, from the lowest: compounds 3, 4 and 1 (each within the scatter of the next, the first and the last beyond it).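

In this assay, among the compounds shown here, compound 1 and compound 4 form the first pair that differs in one place, and putting 4-methoxyphenyl in place of naphthalen-1-yl on a double-bonded chain carbon bound to a double-bonded chain carbon gives a number 5 percentage points lower from compound 1 to compound 4 (within the scatter). Taken alone, then, this change is not resolved by the read-out: a group with one six-membered aromatic ring and one hydrogen-bond acceptor stands here in place of one with two such rings and no acceptor, and the two compounds cannot be told apart. Nothing measured here accounts for this result or shows how either group acts at this position.

On these data alone, it remains open whether any group at this place would separate from naphthalen-1-yl, for instance a 4-aminophenyl ring or a 4-carboxyphenyl ring, since the two groups compared here both carry only carbon-ring aromatic systems without a hydrogen-bond donor. For the compounds shown here, it is also open whether the same exchange would read alike on the butyl-linked compounds, as no pair with that longer chain differs in this one place.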